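The source may hold more compounds than are shown below. What is called first, only, known or untested is meant among the compounds shown, and "the series" means these compounds.

Measured in a functional assay on BT-20 cells (Homo sapiens) for antiproliferative activity, read by trypan blue exclusion; a higher number here means a weaker inhibitor, a lower number a stronger inhibitor:
Compound 1 `COc1ccc(/C=C/S(=O)(=O)Cc2ccc(OC)cc2)cc1`: > 20000 nM, which is a limit of the assay and not a number.
Compound 2 `COc1cc(OC)c(/C=C/S(=O)(=O)Cc2ccc(OC)c(OC)c2OC)c(OC)c1`: 15000 nM.
Compound 3 `COc1cc(OC)c(/C=C/S(=O)(=O)Cc2ccc(Cl)cc2)c(OC)c1`: 10000 nM.

Of the two numbers shown, compound 3 has the lower one; the nearest is compound 2, whose number is higher by an amount within the scatter, so no order between compound 2 and compound 3 can be read from these values. Compound 1 sits at the limit of the assay (the limit of > 20000 nM in this assay, at which 1 of the 3 values shown sits). For the measured compounds named here, no pair of measured compounds differs in only one place, so nothing measured tells how a single change moves the number.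

Compound 4 `COc1cc(OC)c(/C=C/S(=O)(=O)Cc2ccc([N+](=O)[O-])cc2)c(OC)c1` differs from compound 3 by nitro in place of chloro on an aromatic carbon. Going by the values given here, with no measured single-change step to lean on, and with compound 2 and compound 3, which differ in more than one place, still giving numbers within the scatter of each other, the expectation for this assay is a step of no size beyond the scatter, in neither direction. Compound 4 is therefore estimated at 9000 nM, with a range from 3000 nM to 25000 nM. The step this estimate means is a 1.1-fold lower number from compound 3 to compound 4 (0.05 log units; within the scatter), expected to lie within the scatter.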

Compound 4, half-maximal inhibitory concentration: 15000 nM
For compound 4 the middle estimate is 1.7-fold (0.22 log units) below the measured one; low and high end bracket the measured number.
By their numbers in this assay, from the lowest: compounds 3, 2 and 4 (each within the scatter of the next). At a limit, above all of these: compound 1.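

For the compounds shown here, the change from 4-chlorophenyl to 4-nitrophenyl is the first single-change step, and in this assay it gives a 1.5-fold higher number from compound 3 to compound 4 (0.18 log units; within the scatter) on an aromatic carbon para to a large group. At this position the two groups therefore cannot be told apart in this assay, although nitro brings three heavy atoms and two hydrogen-bond acceptors where chloro had one heavy atom and no acceptor. Nothing in the available evidence bears on this step.

From the compounds shown here alone, whether any group at this position can move the number beyond the scatter stays open, since only chloro and nitro can be compared here, and an amine, a carboxylic acid or a longer chain in the same place would test the position more widely. Compound 1 gives > 20000 nM as a limit of the assay and not a number, and with more than one place changed relative to the other compounds, it leaves open which part of the shared core separates it from them.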